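Fluoro for hydrogen on the ether ring of compound 1

The compounds below may be only part of what the source reports. "The series", "measured", "known", "first", "only" and "open" are said of these compounds alone.

Working notes on the series. Compound 1 `O=c1ccn(CCOc2ccccc2)c(=O)n1Cc1ccccc1` is the parent; in an ADME assay on MT4 cells (Homo sapiens) for cytotoxicity, read by MTT assay, with a stated time of 4 days (a lower number here means that less compound is tolerated, a higher number that more compound is tolerated), compound 1 gives 193000 nM. Of the three numbers shown it is the largest, yet the two neighbours sit within the scatter: compound 2 `Cc1ccccc1OCCn1ccc(=O)n(Cc2ccccc2)c1=O` gives 117000 nM and compound 3 `Cc1ccc(OCCn2ccc(=O)n(Cc3ccccc3)c2=O)cc1` gives 187000 nM. The measured steps are flat: a 1.6-fold lower number from compound 1 to compound 2 (0.22 log units; within the scatter) and a 1.0-fold lower number from compound 1 to compound 3 (0.01 log units; within the scatter), and between the two methylated compounds a 1.6-fold higher number from compound 2 to compound 3 (0.20 log units; within the scatter).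

Compound 4 `O=c1ccn(CCOc2ccc(F)cc2)c(=O)n1Cc1ccccc1` is the unmeasured member. It differs from compound 1 by fluoro in place of hydrogen on an aromatic carbon, a fluoro placed para to a large group on the six-membered aromatic ring of carbon only. Among the measured compounds shown here, the steps that bear on it are those from compound 1 to compound 2 and to compound 3, where methyl in place of hydrogen on an aromatic carbon changed nothing beyond the scatter. Fluoro in place of hydrogen at the same ring is a smaller addition than methyl, so no step beyond the scatter is expected: the estimated step is a 1.1-fold lower number from compound 1 to compound 4 (0.03 log units; within the scatter). Compound 4 is therefore expected to give about 180000 nM, within the range 100000 nM to 320000 nM.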

Compound 4, half-maximal cytotoxic concentration: 187000 nM
Compound 4: the middle estimate sits 1.0-fold (0.02 log units) below what was measured; the range from low to high includes it.
By their numbers in this assay, from the lowest: compounds 2, 3, 4 and 1 (each within the scatter of the next).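

In this assay, fluoro para to a large group joins methyl as a change at this place that stays within the scatter, with the parent step reading (a 1.0-fold lower number from compound 1 to compound 4 (0.01 log units; within the scatter)). The new compound also shows that exchanging one of these small groups for the other leaves the printed number unmoved (no change at the digits printed from compound 3 to compound 4 (within the scatter)), and the comparison with the 2-methylphenyl compound likewise stays within the scatter (a 1.6-fold higher number from compound 2 to compound 4 (0.20 log units; within the scatter)). Nothing available explains why these numbers stay so flat.

The compounds shown leave open whether this place stays as flat with an amine, a carboxylic acid or a longer chain in place of the hydrogen. They also leave open whether 2-fluorophenyl reads like 4-fluorophenyl on the same oxygen.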